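Changing the group on the ring nitrogen: compound 2 to compound 3

The source may hold more compounds than are shown below. What is called first, only, known or untested is meant among the compounds shown, and "the series" means these compounds.

Compound 2 `COc1cc(NC(=O)Nc2cc(Nc3cc(Br)ccc3OC)ncn2)cc(OC)c1` stands highest of the two compounds measured in a functional assay on NCI-H520 cells (Homo sapiens) for inhibition, read by MTT assay, with a stated time of 48 h, tested at 10 uM (a higher number here means more inhibition at the concentration tested (going by the name of the read-out), a lower number less inhibition), where compound 2 gives 43.5%. Compound 1 `COc1cc(NC(=O)Nc2cc(Nc3ccc(C)c(C)c3)ncn2)cc(OC)c1` gives 29.5% in this assay. Within the data shown here, the only step known at this place was modest, a number 14 percentage points higher from compound 1 to compound 2 (beyond the scatter), and it concerned the group on a nitrogen on an aromatic ring. Compound 3 `COc1cc(NC(=O)Nc2cc(Nc3ccc(OC)c(C)c3)ncn2)cc(OC)c1` alters that same group: 4-methoxy-3-methylphenyl in place of 5-bromo-2-methoxyphenyl on a nitrogen on an aromatic ring. A modest fall, or no change beyond the scatter, is expected, a number 8.5 percentage points lower from compound 2 to compound 3 (within the scatter). Compound 3 is therefore estimated to give about 35%, within a range from 20% to 50%.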

Compound 3, a percentage reported as inhibition, at one concentration (the size of the read-out at that concentration, not a potency): 13.5%
Compound 3: middle estimate off by 21.5 percentage points, on the high side; measured number below the stated range.
By their numbers in this assay, from the lowest: compound 3; then compound 1; then compound 2.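

The group on the nitrogen can also push the number down in this assay, with a number 30 percentage points lower from compound 2 to compound 3 (beyond the scatter) when 4-methoxy-3-methylphenyl replaces 5-bromo-2-methoxyphenyl. A single exchange on that ring matters too, with a number 16 percentage points lower from compound 1 to compound 3 (beyond the scatter) for methoxy in place of methyl, so a methoxy group alone does not go with a higher number. Nothing measured here accounts for these differences.
As far as these compounds go, it remains open whether the bromine or the methoxy of compound 2 goes with its higher number, and how a chlorine atom, an amine or a morpholine ring would read at that position.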